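Swapping 4-bromophenyl for cyclopropyl in the series

The source may report more compounds than this note shows. Statements on the series, on what has been measured and on what is new or still open speak of the compounds shown alone.

Measured so far:
Compound 1 `COc1ccccc1C(=O)Nc1nc(-c2cc(OC)c(OC)c(OC)c2)cs1` gives 8500 nM
Compound 2 `Cn1c(-c2ccc(Br)cc2)cs/c1=N\C(=O)c1ccccc1` gives 125 nM

Compound 2 at 125 nM holds the lower of the two numbers in a functional assay on MDA-MB-231 cells (Homo sapiens), read by microscopy and transwell migration, with a stated time of 24 h (on this read-out higher numbers stand for weaker inhibition and lower numbers for stronger inhibition), and its gap to compound 1 at 8500 nM lies beyond the scatter. The next compound to be read is compound 3 `Cn1c(C2CC2)cs/c1=N\C(=O)c1ccccc1` which differs from compound 2 by cyclopropyl in place of 4-bromophenyl on an aromatic carbon of the shared core. Going by the values given here, no measured pair differs in one place, so this expectation rests thinly on compound 2 at 125 nM standing low, where a single change has more room to raise the number than to lower it. A step beyond the scatter toward weaker inhibition is expected in this assay with a 12-fold higher number from compound 2 to compound 3 (1.08 log units; beyond the scatter) as the estimated size. In this assay the estimate for compound 3 is 1500 nM with an expected range from 250 nM to 9000 nM for now.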

Compound 3, half-maximal inhibitory concentration: 104 nM
Beside the measured number, compound 3's estimate is 14-fold (1.16 log units) above it; measured number outside the range, below it.
By their numbers in this assay, from the lowest: compounds 3 and 2 (each within the scatter of the next); then compound 1.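

In this assay, the step of a 1.2-fold lower number from compound 2 to compound 3 (0.08 log units; within the scatter) shows that, at this aromatic carbon next to the ring nitrogen, the two groups cannot be told apart. A number of this size at this position therefore does not depend on the 4-bromophenyl: its 7 heavy atoms, including the bromine and the six-membered aromatic ring, can give way to the 3 carbon atoms of cyclopropyl with the read-out staying within the scatter. Nothing in hand explains why these two groups read alike.

Both groups carry 0 hydrogen-bond donors and 0 hydrogen-bond acceptors, so the compounds shown leave open how an amine or a carboxylic acid would read at this position. On these data alone, whether a longer alkyl chain in place of cyclopropyl would hold the number also remains open.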